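Moving the methoxy group on a ring-nitrogen aryl substituent

A few compounds are considered here, and "the series" means these few. Any claim that something is new, unique, unknown or untested is made for them only; others in the source may bear on it.

Compound 1 `O=C1COc2ccc(-c3cnc(Cl)c(NS(=O)(=O)c4ccc(F)cc4)c3)cc2N1c1ccccc1`: 36900 nM
Compound 2 `O=C1COc2ccc(-c3ccc(O)cc3)cc2N1`: > 40000 nM (a limit)
Compound 3 `COc1ccc(N2C(=O)COc3ccc(-c4ccc(O)cc4)cc32)cc1`: > 40000 nM (a limit)

In a functional assay on A-375 cells (Homo sapiens) for antiproliferative activity, read by MTT assay, with a stated time of 72 h (on this read-out lower numbers stand for stronger inhibition and higher numbers for weaker inhibition), compound 1 gives 36900 nM. Compound 2 reaches only the limit of the assay, > 40000 nM. Compound 3 likewise gives only a limit, > 40000 nM. Where compound 3 stands is thus not a number but a limit; it sits at the limit of > 40000 nM in this assay, at which 2 of the 3 values shown sit. For the measured compounds named here, the only measured step at the same position is a step that the two limits leave unreadable from compound 2 to compound 3, 4-methoxyphenyl in place of hydrogen on an amide-type nitrogen in a ring.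

Compound 4 `COc1cccc(N2C(=O)COc3ccc(-c4ccc(O)cc4)cc32)c1` has not been measured; its difference from compound 3 is 3-methoxyphenyl in place of 4-methoxyphenyl on an amide-type nitrogen in a ring. Going by the values given here, no measured step bears directly on this change, and the one step at that nitrogen, a step that the two limits leave unreadable from compound 2 to compound 3, is unreadable, so no step beyond the scatter can be expected in this assay in either direction. Compound 4 is expected to give 45000 nM, between 20000 nM and 120000 nM, most likely again only a limit. The implied step, a step that the limit leaves unreadable from compound 3 to compound 4, is expected to lie within the scatter.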

Compound 4, half-maximal inhibitory concentration: 30400 nM
Compound 4: middle estimate off by 1.5-fold (0.17 log units), on the high side; the measured number falls inside the stated range.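

With compound 4, the 3-methoxyphenyl group on the amide-type nitrogen gives a number rather than a limit in this assay, which neither compound 2 nor compound 3 did. The methoxy change at this nitrogen can now be read in one direction: moving the group gives an at least 1.3-fold lower number from compound 3 to compound 4 (0.11 log units; that floor lies within the scatter), and replacing the hydrogen with 3-methoxyphenyl gives an at least 1.3-fold lower number from compound 2 to compound 4 (0.11 log units; that floor lies within the scatter). Neither floor shows a gain beyond the scatter, and the true size of both steps stays unknown because the starting compounds rest at a limit: the limit of > 40000 nM in this assay, at which 2 of the 4 values shown sit.

Still open, on these data alone, is whether an amine or a carboxylic acid in place of the methoxy group would move the number beyond the scatter. Also open, as far as these compounds go, is what the 3-methoxyphenyl group would do on the core of compound 1.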